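Bromo in place of hydrogen on the phenyl of compound 3

This account rests on a few compounds, and the source may have more. Where it says the series, first, only, none or still open, it means among the compounds named here.

Compound 3 `CC1(C)[C@H]2CC[C@]1(C)N(Cc1cn(-c3ccccc3)nn1)C(=O)C2` stands, in a functional assay on OVCAR-3 cells (Homo sapiens) for inhibition, read by MTT assay, with a stated time of 24 h (a lower number here means a stronger inhibitor, a higher number a weaker inhibitor), at 50 nM, level with compound 1 `CC1(C)[C@H]2CC[C@]1(C)N(Cc1cn(-c3cccc(Cl)c3)nn1)C(=O)C2`, which in this assay gives 50 nM; together they hold the lowest numbers of the three measured, while compound 2 `Cc1ccccc1-n1cc(CN2C(=O)C[C@@H]3CC[C@@]2(C)C3(C)C)nn1` gives 150 nM. The step of a 3.0-fold lower number from compound 2 to compound 3 (0.48 log units; beyond the scatter) lies beyond the scatter, as does a 3.0-fold higher number from compound 1 to compound 2 (0.48 log units; beyond the scatter), whereas no change at the digits printed from compound 1 to compound 3 (within the scatter) stays within it.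

Compound 4 `CC1(C)[C@H]2CC[C@]1(C)N(Cc1cn(-c3cccc(Br)c3)nn1)C(=O)C2` differs from compound 3 by bromo in place of hydrogen on an aromatic carbon. Among the compounds with values here, the step that bears most directly on this change is the one between compound 1 and compound 3, where chloro gave way to hydrogen at the same place and the number did not move: no change at the digits printed from compound 1 to compound 3 (within the scatter). A halogen at that position therefore appears, on this evidence, to leave the number where it is, and no step beyond the scatter is expected here; the expected step is no change at the digits printed from compound 3 to compound 4 (within the scatter). Compound 4 is accordingly estimated at 50 nM, with a range from 25 nM to 100 nM.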

Compound 4, half-maximal inhibitory concentration: 30 nM
For compound 4 the middle estimate is 1.7-fold (0.22 log units) above the measured one; measured number inside the range.
By their numbers in this assay, from the lowest: compounds 4, 1 and 3 (each within the scatter of the next); then compound 2.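

In this assay, compound 4 makes bromo the second halogen on this aromatic carbon to stay within the scatter of the unsubstituted phenyl, with a 1.7-fold lower number from compound 3 to compound 4 (0.22 log units; within the scatter), and the exchange of chloro for bromo also stays within it, with a 1.7-fold lower number from compound 1 to compound 4 (0.22 log units; within the scatter). Compound 2 remains set apart from the halogen-bearing compounds, now also by a 5.0-fold lower number from compound 2 to compound 4 (0.70 log units; beyond the scatter), although that step exchanges the whole 2-methylphenyl for 3-bromophenyl and so cannot separate the identity of the group from its place on the ring. Nothing available explains these numbers.

The compounds shown leave open whether this tolerance extends beyond halogens to a methoxy group, an amine or a carboxylic acid on the same carbon. They also leave open how bromo would read on another carbon of the ring.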